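Ring swap on the fluoro series: working notes

A few compounds are considered here, and "the series" means these few. Any claim that something is new, unique, unknown or untested is made for them only; others in the source may bear on it.

Measured in a physicochemical assay for lipophilicity, using the shake flask method, measured as octanol-water partition, at pH 7.4; on this read-out higher numbers stand for higher lipophilicity and lower numbers for lower lipophilicity:
- compound 1 `CC(=O)N[C@@H]1CCC[C@H](C(=O)Nc2cc(-c3cnn4c3CCCC4)c(F)cn2)C1`: 2.9
- compound 2 `CC(=O)N[C@@H]1CCC[C@H](C(=O)Nc2cc(-c3cnn4c3CCCC4)c(Cl)cn2)C1`: 3.2

Within the data shown here, only two numbers exist so far, and they do not separate. Among the measured compounds shown here, compound 1, at 2.9, stands within the scatter of compound 2, and the single measured step is a number 0.30 log units higher from compound 1 to compound 2 (within the scatter).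

The next compound is compound 3 `CC(=O)N[C@@H]1CCC[C@H](C(=O)Nc2cc(-c3cnn4c3CC(C)(C)C4)c(F)cn2)C1`. The change is a group of 10 heavy atoms (8 carbon, 2 nitrogen; one five-membered non-aromatic ring with 1 hetero atom, one five-membered aromatic ring with 2 hetero atoms) in place of a group of 9 heavy atoms (7 carbon, 2 nitrogen; one five-membered aromatic ring with 2 hetero atoms, one six-membered non-aromatic ring with 1 hetero atom), on an aromatic carbon, ortho to a fluoro group and opposite the ring nitrogen. The fluoro group itself stays in place.

For the measured compounds named here, the one measured step, chloro in place of fluoro, leaves this group untouched, so no measured step speaks to the swap directly. It offers only a sense of scale for a small edit in this series, and that step stayed within the scatter. With so little evidence, a small upward move in this assay is expected, not clearly beyond the scatter. The expected step is a number 0.20 log units higher from compound 1 to compound 3 (within the scatter). For compound 3 the estimated value is 3.1, with an expected range from 2.7 to 3.5.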

Compound 3, distribution coefficient: 3.3
For compound 3 the middle estimate is 0.20 log units below the measured one, within the range that was stated.
By their numbers in this assay, from the lowest: compounds 1, 2 and 3 (each within the scatter of the next, the first and the last beyond it).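

In this assay, among these compounds, the swap on the aromatic carbon opposite the ring nitrogen gives a number 0.40 log units higher from compound 1 to compound 3 (beyond the scatter), and this is the first step to lie beyond the scatter, whereas the earlier edit at the halogen gave a number 0.30 log units higher from compound 1 to compound 2 (within the scatter). The read-out is therefore measurably responsive to a change at this position on the fluoro series, although the step is modest and rests on a single pair of compounds. No measurement at hand bears on what lies behind the step.

The swap alters two things at once, replacing the six-membered non-aromatic ring with a five-membered non-aromatic ring and the group of 9 heavy atoms with the group of 10 heavy atoms, so the compounds shown leave open how much of the step belongs to ring size and how much to the added carbon. Also open, as far as these compounds go, are whether the step carries over with chloro in place of fluoro, and how the read-out would respond to a hydroxyl group or an amine on the non-aromatic ring.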